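The source may report more compounds than this note shows. Statements on the series, on what has been measured and on what is new or still open speak of the compounds shown alone.

Measured compounds:
- compound 1, `COc1cc(N(CC(C)(C)O)c2cccc(C(F)(F)F)c2)cnc1C(=O)[C@H]1C[C@@H]1C(=O)O`, in an ADME assay on cells (Hepatocyte, Homo sapiens) for metabolic stability, read by LC-MS, with a stated time of 60 min, tested at 1 uM (a lower number here means slower removal, a higher number faster removal of the compound), compound 1 gives "not determined" (no result reported)
- compound 2, `CCCN(c1cccc(C(F)(F)F)c1)c1cnc(C(=O)[C@H]2C[C@@H]2C(=O)O)c(OC)c1`, in this assay compound 2 gives 7.2 uL/min

Within the data shown here, compound 2 carries the only number in this assay within this pair; compound 1 stands beside it without a result, so no step between measured compounds is available and nothing can be said of how the two compare. Compound 2 therefore serves as the only anchor for the series in this assay.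

The next compound is compound 3, `COc1cc(N(Cc2ccc(F)cc2)c2cccc(C(F)(F)F)c2)cnc1C(=O)[C@H]1C[C@@H]1C(=O)O`. Its difference from compound 2 is 4-fluorophenyl in place of ethyl on a saturated chain carbon bound to a nitrogen on an aromatic ring; cut one bond further out, the same change reads propyl to 4-fluorobenzyl. The shared core and the remaining substituents on the nitrogen are unchanged.

Among the measured compounds shown here, with no measured step in hand, the expectation for this assay rests on the value of compound 2 alone. The step from compound 2 to compound 3 is expected to be a 1.9-fold higher number from compound 2 to compound 3 (0.29 log units; within the scatter), that is a moderate rise in clearance, roughly at the edge of the usual scatter rather than clearly beyond it. Compound 3 is accordingly estimated at 14 uL/min, with a range from 6 uL/min to 32 uL/min.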

Compound 3, intrinsic clearance in a liver preparation (reported as CLH), per the amount of preparation that the assay uses in the Hepatocyte assay: 4.2 uL/min
Compound 3: middle estimate off by 3.3-fold (0.52 log units), on the high side, and the stated range ends above it.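

Among these compounds, the first measured step at this position reads, in the Hepatocyte assay, a 1.7-fold lower number from compound 2 to compound 3 (0.23 log units; within the scatter), so 4-fluorophenyl in place of ethyl on a saturated chain carbon bound to a nitrogen on an aromatic ring gives no change in clearance that can be told from the scatter. In a physicochemical assay for lipophilicity, read by LC-MS, in phosphate buffer, measured as octanol-water partition, at pH 7.4 (a higher number here means a more lipophilic compound, a lower number a more polar compound), compound 2 gives 1.2 and compound 3 gives 1.9, so the same change does register in the second read-out. In the Hepatocyte assay removal of compound 3 is not separated from that of compound 2, although compound 3 is the more lipophilic of the two in the physicochemical assay: the measured distribution coefficient of compound 2, 1.2, and of compound 3, 1.9, a number 0.70 log units higher (beyond the scatter)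

On these data alone, one step gives no trend, so it stays open whether clearance would hold with an unsubstituted benzyl, a longer chain or a chain carrying an amine in this place. The hydroxyl-bearing chain of compound 1 adds nothing to the comparison, since in the Hepatocyte assay compound 1 gives "not determined" (no result reported).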